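A few compounds are considered here, and "the series" means these few. Any claim that something is new, unique, unknown or untested is made for them only; others in the source may bear on it.

Measured compounds:
- Compound 1 `COc1cc(/C=C/C(=O)OCCCO[N+](=O)[O-])ccc1OCCCO[N+](=O)[O-]`: > 50000 nM
- Compound 2 `COc1cc(/C=C/C(=O)OC(C)CCOc2no[n+]([O-])c2S(=O)(=O)c2ccccc2)ccc1O`: 400 nM
- Compound 3 `COc1cc(/C=C/C(=O)OCCCO[N+](=O)[O-])ccc1O`: 17200 nM

All three were tested in a functional assay on SKBR cells (Homo sapiens) for cytotoxicity, read by resazurin assay, with a stated time of 72 h; on this read-out higher numbers stand for weaker inhibition and lower numbers for stronger inhibition. Compound 1 reads > 50000 nM, which is a limit and not a number. Going by the values given here, it is the only compound in this set that gives a limit: the limit of > 50000 nM in this assay, at which 1 of the 3 values shown sits.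

Compound 4 `O=C(/C=C/c1ccc(OCCCO[N+](=O)[O-])c(O)c1)OCCCO[N+](=O)[O-]` is still unmeasured. It differs from compound 1 in one place, with hydrogen in place of methyl on an oxygen on an aromatic ring, so that methoxy becomes hydroxy (hydrogen in place of methyl on an oxygen on an aromatic ring).

Among the compounds with values here, no measured step makes this exact change. The closest one also leaves a free hydroxy on the ring, but by a different swap, hydrogen in place of 3-(nitrooxy)propyl: an at least 2.9-fold lower number from compound 1 to compound 3 (0.46 log units; beyond the scatter). On these data alone, that step starts from a limit, so its true size remains open. Within the data shown here, compound 2 is joined to the others by no single-place step and gives no guide here.

Going by the step to compound 3 at 17200 nM, a change of modest size towards a lower number is expected in this assay. The expected step is an at least 2.2-fold lower number from compound 1 to compound 4 (0.35 log units; beyond the scatter). For compound 4 the estimated value is 22000 nM, with an expected range from 8000 nM to 50000 nM.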

Compound 4, half-maximal inhibitory concentration: 4810 nM
Beside the measured number, compound 4's estimate is 4.6-fold (0.66 log units) above it; measured number outside the range, below it.
By their numbers in this assay, from the lowest: compound 2; then compound 4; then compound 3. At a limit, above all of these: compound 1.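

Hydrogen in place of methyl on an oxygen on an aromatic ring, which turns methoxy into hydroxy, now has a measured step of its own in this assay: an at least 10-fold lower number from compound 1 to compound 4 (1.01 log units; beyond the scatter), a large change for the loss of a single carbon. The earlier compounds showed a free hydroxy only through a different swap, the loss of 3-(nitrooxy)propyl, which gave an at least 2.9-fold lower number from compound 1 to compound 3 (0.46 log units; beyond the scatter), a step of at least modest size, so this methoxy is now shown to matter in its own right. The true size of the new step stays open because compound 1 gives only a limit and not a number: the limit of > 50000 nM in this assay, at which 1 of the 4 values shown sits.

On these data alone, whether the lower number follows from gaining the hydroxy or from losing the methyl remains open, and an ethoxy or an amine at this place could help to separate the two. As far as these compounds go, it is also open whether the same swap would give a step of similar size with a longer chain in place of the 3-(nitrooxy)propyl groups.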